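The source may hold more compounds than are shown below. What is called first, only, known or untested is meant among the compounds shown, and "the series" means these compounds.

Working notes on the series. Compound 1 `O=C(CCl)Nc1cccc(-c2nc3ccccc3s2)c1` and compound 2 `O=C(Nc1cccc(-c2nc3ccccc3s2)c1)c1cnccc1Cl` share one core and differ only at the carbonyl carbon. In an ADME assay on HepG2 cells (Homo sapiens) for inhibition, with a stated time of 72 h (a higher number here means that more compound is needed for the effect, a lower number that less compound is needed), compound 1 gives 16000 nM. Compound 2 reaches only the assay limit there, giving > 25000 nM. Among the compounds with values here, the one measured step, an at least 1.5-fold higher number from compound 1 to compound 2 (0.19 log units; that floor lies within the scatter), is bounded because of the limit of > 25000 nM in this assay, at which 1 of the 2 values shown sits. Compound 2 therefore stands at the limit in this assay with no number of its own. Compound 3 `COc1ccc(-c2nc3ccccc3s2)cc1NC(=O)c1cnccc1Cl` carries methoxy in place of hydrogen on an aromatic carbon. Within the data shown here, no measured step touches that aromatic carbon; the one measured step concerns the carbonyl carbon and has no known size. Nothing shown supports a step in either direction beyond the scatter in this assay, and with compound 2 already at the limit a reported number for compound 3 is doubtful. Compound 3 is expected to show a step that the limit leaves unreadable from compound 2 to compound 3 in this assay. The estimate for compound 3 is 30000 nM, between 12000 nM and 80000 nM.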

Compound 3, half-maximal effective concentration: > 25000 nM
Compound 3 gave a limit, no number (the forecaster's own chance of this, stated with the estimate: 70%); the middle value is on the limit's open side.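

In this assay, within the data shown here, compound 3 gives > 25000 nM as a limit, not a number, so no step from compound 2 to compound 3 can be read: the limit of > 25000 nM in this assay, at which 2 of the 3 values shown sit. Whether methoxy in place of hydrogen on an aromatic carbon changes the number in this assay stays open in the compounds shown.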